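The source may report more compounds than this note shows. Statements on the series, on what has been measured and on what is new or still open speak of the compounds shown alone.

Compound 1 `Cc1cc(CO)nc(NNC(=O)Nc2cc(Cl)nc(Cl)c2)c1` and compound 2 `Cc1cc(NNC(=O)Nc2cc(Cl)nc(Cl)c2)nc(C(=O)N(C)C)c1` share one core. In a functional assay on CHO cells for antagonist activity at sphingosine 1-phosphate receptor 2 (Homo sapiens), read by fluorescence and calcium flux, with a stated time of 3 min (on this read-out higher numbers stand for weaker inhibition and lower numbers for stronger inhibition), compound 1 gives only a limit, > 6600 nM. In this assay compound 2 likewise gives only a limit, > 19000 nM. The step that the two limits leave unreadable from compound 1 to compound 2 thus cannot be read in either direction. Compound 3 `Cc1cc(NNC(=O)Nc2cc(Cl)nc(Cl)c2)nc(C(=O)NC2CC2)c1` differs from compound 2 by cyclopropylamino in place of dimethylamino on a carbonyl carbon. Among the compounds with values here, no measured step bears on this change, and the one neighbouring step is unreadable, so compound 2 stands at a limit with nothing to anchor a direction. Compound 3 is expected to give 20000 nM, within 5000 nM to 80000 nM, most likely again as a limit, the expected step that the limit leaves unreadable from compound 2 to compound 3 being of no readable size.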

Compound 3, half-maximal inhibitory concentration: 4500 nM
Compound 3: the middle estimate sits 4.4-fold (0.65 log units) above what was measured; measured number outside the range, below it.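

In this assay, within the data shown here, the change at this carbonyl carbon gives the first readable step: cyclopropylamino in place of dimethylamino is an at least 4.2-fold lower number from compound 2 to compound 3 (0.62 log units; beyond the scatter). That size is only a floor, since compound 2 gives only a limit: the limit of > 19000 nM in this assay, at which 1 of the 3 values shown sits. The other new step, an at least 1.4-fold lower number from compound 1 to compound 3 (0.16 log units; that floor lies within the scatter), fixes no order.

The compounds shown leave open whether the step follows the three-membered ring or the amide hydrogen that enters with it. Methylamino on the same carbonyl carbon would separate the two.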